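Vero cytotoxicity notes: bromo to isopropyl on the pendant phenyl

This account rests on a few compounds, and the source may have more. Where it says the series, first, only, none or still open, it means among the compounds named here.

The series comprises compound 1 `CC1(c2ccc(Nc3nc(N4CCCc5ccccc54)nc(N4CCCc5ccccc54)n3)cc2)NC(=O)c2ccccc2N1`, compound 2 `CCCCNC(c1ccc(C2NC(=O)c3ccccc3N2)cc1)c1nnnn1C(C)(C)C`, compound 3 `CC1(c2ccc(NC(c3ccc(Br)cc3)c3nnnn3C3CCCCC3)cc2)NC(=O)c2ccccc2N1` and the unmeasured compound 4 `CC(C)c1ccc(C(Nc2ccc(C3(C)NC(=O)c4ccccc4N3)cc2)c2nnnn2C2CCCCC2)cc1`. In an ADME assay on Vero cells (Chlorocebus sabaeus) for cytotoxicity, read by MTT assay, with a stated time of 72 h (a lower number here means that less compound is tolerated, a higher number that more compound is tolerated), compound 1 gives "not determined" (no result reported). In this assay compound 2 likewise gives "not determined" (no result reported). Compound 3 reaches only a limit of the assay, > 400000 nM, and so stands at the top of what this assay reports, consistent with the limit of > 400000 nM in this assay, at which 1 of the 3 values shown sits. For the measured compounds named here, no step between measured compounds exists here. Compound 4 differs from compound 3 by isopropyl in place of bromo on an aromatic carbon. Going by the values given here, with no measured step to draw on, the expected change from compound 3 to compound 4 is a number no higher from compound 3 to compound 4 (the limit leaves the size open), none beyond the scatter. Compound 4 is therefore estimated at 400000 nM, within 150000 nM to 800000 nM, most likely again as a limit.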

Compound 4, half-maximal cytotoxic concentration: > 400000 nM
Compound 4: only a limit was reported; the forecaster's own chance of this, stated with the estimate: 70%; the middle value lies on the limit itself.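

For the compounds shown here, compound 3 and compound 4 both stand only as limits in this assay, and no step between them can be read. The compounds shown leave open whether 4-bromophenyl and 4-isopropylphenyl differ at all in tolerated concentration.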